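Cyano for trifluoromethyl on the anilide ring of compound 3

The source may report more compounds than this note shows. Statements on the series, on what has been measured and on what is new or still open speak of the compounds shown alone.

Measured compounds:
compound 1 `N#Cc1cccc(Nc2ncc(C(=O)c3ccccc3F)s2)c1` 19 nM
compound 2 `Cc1ccccc1C(=O)c1cnc(Nc2cccc(C(F)(F)F)c2)s1` 63 nM
compound 3 `CCc1ccccc1C(=O)c1cnc(Nc2cccc(C(F)(F)F)c2)s1` 32 nM

In an assay for inhibition of Neuropeptide Y receptor type 5 (Mus musculus) (a higher number here means a weaker inhibitor, a lower number a stronger inhibitor), compound 3 gives 32 nM, the second highest of the three numbers. Going by the values given here, its nearest neighbour is compound 1 with 19 nM, within the scatter; compound 2 with 63 nM is also within the scatter, the only measured step being a 2.0-fold lower number from compound 2 to compound 3 (0.29 log units; within the scatter).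

Compound 4 `CCc1ccccc1C(=O)c1cnc(Nc2cccc(C#N)c2)s1` differs from compound 3 by cyano in place of trifluoromethyl on an aromatic carbon. Among the compounds with values here, no measured step bears directly on this change: compound 1 carries the cyano group on the same ring, but it also differs from compound 3 in the group on the ketone-bearing ring, so its two values with compound 3 show only that the cyano-bearing compound 1 and the trifluoromethyl-bearing compound 3 sit within the scatter of each other. Within the data shown here, with no direct precedent, and the whole set spanning a narrow range, no step beyond the scatter is expected in this assay. Compound 4 is therefore estimated at 25 nM, range 10 nM to 65 nM, meaning an expected step of a 1.3-fold lower number from compound 3 to compound 4 (0.11 log units; within the scatter).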

Compound 4, half-maximal inhibitory concentration: 2.8 nM
Compound 4: the middle estimate sits 8.9-fold (0.95 log units) above what was measured, and the stated range ends above it.
By their numbers in this assay, from the lowest: compound 4; then compounds 1, 3 and 2 (each within the scatter of the next, the first and the last beyond it).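

In this assay, going by these compounds alone, the aromatic carbon bearing the trifluoromethyl group turns out to be sensitive to its substituent: cyano in its place gives an 11-fold lower number from compound 3 to compound 4 (1.06 log units; beyond the scatter), a large step and the first single change at this carbon that the series can read. With cyano held constant, ethyl in place of fluoro on the ketone-bearing ring gives a 6.8-fold lower number from compound 1 to compound 4 (0.83 log units; beyond the scatter), a modest step, so a change on that ring also registers once the nitrile is present. Nothing available on these compounds accounts for either step.

Whether cyano gives a similar step with fluoro on the ketone-bearing ring remains open, as the compounds shown offer no trifluoromethyl partner for compound 1. Also open, on these data alone, is how a methoxy group or a primary carboxamide would compare with cyano on this same aromatic carbon.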